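Cyclobutyl in Place of 3-Methoxyphenyl on the Piperidine Benzamide

A few compounds are considered here, and "the series" means these few. Any claim that something is new, unique, unknown or untested is made for them only; others in the source may bear on it.

Measured compounds:
compound 1 `CCCCCCCN1CCC(C(=O)Nc2cc(Cl)c(N)cc2OC)CC1` — > 10 mg/kg
compound 2 `COc1cc(N)c(Cl)cc1NC(=O)C1CCN(Cc2ccccc2F)CC1` — > 4 mg/kg
compound 3 `COc1cccc(CN2CCC(C(=O)Nc3cc(Cl)c(N)cc3OC)CC2)c1` — > 4 mg/kg

Three compounds sharing one core were tested in a functional assay on the whole organism for antagonist activity, with Mus musculus as the target; on this read-out higher numbers stand for an effect only at larger amounts of compound and lower numbers for an effect already at smaller amounts. Compound 1 `CCCCCCCN1CCC(C(=O)Nc2cc(Cl)c(N)cc2OC)CC1` gives only a limit of the assay, > 10 mg/kg. Compound 2 `COc1cc(N)c(Cl)cc1NC(=O)C1CCN(Cc2ccccc2F)CC1` likewise gives only a limit, > 4 mg/kg. Compound 3 `COc1cccc(CN2CCC(C(=O)Nc3cc(Cl)c(N)cc3OC)CC2)c1` also gives only a limit, > 4 mg/kg, so its standing among the three cannot be placed; all three values are limits, one at the limit of > 10 mg/kg in this assay, at which 1 of the 3 values shown sits, and two at the limit of > 4 mg/kg in this assay, at which 2 of the 3 values shown sit.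

The steps between the measured compounds are therefore unreadable: a step that the two limits leave unreadable from compound 1 to compound 2, a step that the two limits leave unreadable from compound 1 to compound 3 and a step that the two limits leave unreadable from compound 2 to compound 3. None of them tells how a change at this position moves the read-out.

Compound 4 `COc1cc(N)c(Cl)cc1NC(=O)C1CCN(CC2CCC2)CC1` has not yet been measured. It differs from compound 3 by cyclobutyl in place of 3-methoxyphenyl on a saturated chain carbon bound to an amine nitrogen in a ring. Among the measured compounds shown here, the change sits at the same place as the three unreadable steps, which bear on it only by showing that no measured compound has yet given a number there. No direction can be expected beyond the scatter.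

Compound 4 is expected to lie near 6 mg/kg, within 3 mg/kg to 15 mg/kg, with a considerable chance that this assay again returns only a limit; the estimated step that the limit leaves unreadable from compound 3 to compound 4 is one of no clear size.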

Compound 4, dose for half-maximal effect: > 10 mg/kg
Compound 4: no number, only a limit; the forecaster's own chance of this, stated with the estimate: 75%; middle value at least 1.6-fold (0.22 log units) from the limit.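

In this assay compound 4 gives only a limit, as do compound 1, compound 2 and compound 3, so none of the steps from these three to compound 4 can be read. The compounds shown leave open whether any group on a saturated chain carbon bound to an amine nitrogen in a ring moves the read-out, and in which direction.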